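The compounds below may be only part of what the source reports. "The series", "measured", "known", "first", "only" and "open" are said of these compounds alone.

Compound 1 `CN(C)Cc1ccc(NC(=O)Nc2ccc3ncnc(Nc4cccc(C(F)(F)F)c4)c3c2)cc1`, compound 2 `O=C(Nc1cccc(CN2CCCC2)c1)Nc1ccc2ncnc(Nc3cccc(C(F)(F)F)c3)c2c1` and compound 3 `Cc1ccc(NC(=O)Nc2ccc3ncnc(Nc4cccc(C(F)(F)F)c4)c3c2)cc1` share one core and differ only in the ring carried by the urea. In a functional assay on A549 cells (Homo sapiens) for antiproliferative activity, read by MTT assay, with a stated time of 72 h (a higher number here means a weaker inhibitor, a lower number a stronger inhibitor), compound 1 gives 1120 nM, compound 2 gives 860 nM and compound 3 gives 4140 nM, the highest of the three numbers. Going by the values given here, the steps that bear on the next change are a 3.7-fold higher number from compound 1 to compound 3 (0.57 log units; beyond the scatter) and a 4.8-fold higher number from compound 2 to compound 3 (0.68 log units; beyond the scatter); each replaces a chain bearing an amine with a plain group, and each raises the number. Compound 4 `COc1ccc(NC(=O)Nc2ccc3ncnc(Nc4cccc(C(F)(F)F)c4)c3c2)cc1` keeps a plain group; the change is methoxy in place of methyl on an aromatic carbon, which brings no amine back. Among the compounds with values here, no measured step tests a methoxy here, so only a small step is expected, a 1.2-fold lower number from compound 3 to compound 4 (0.07 log units; within the scatter). In this assay compound 4 is expected to give 3500 nM, within 1500 nM to 8500 nM.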

Compound 4, half-maximal inhibitory concentration: 9470 nM
Compound 4: middle estimate off by 2.7-fold (0.43 log units), on the low side; measured number outside the range, above it.
By their numbers in this assay, from the lowest: compounds 2 and 1 (each within the scatter of the next); then compound 3; then compound 4.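

Methoxy in place of methyl gives a 2.3-fold higher number from compound 3 to compound 4 (0.36 log units; beyond the scatter) and brings no amine into play, so even two plain groups at this place on the ring are not interchangeable. In this assay the gap to the amine-bearing compounds also grows, with an 11-fold higher number from compound 2 to compound 4 (1.04 log units; beyond the scatter) and an 8.5-fold higher number from compound 1 to compound 4 (0.93 log units; beyond the scatter) against the smaller steps these two compounds show to compound 3. Going by these compounds, whether a fluorine atom, a hydroxyl or a carboxylic acid at this place would lower or raise the number stays open. No measurement shown gives a reason for the methoxy step.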